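Swapping a phenyl for a 3-(methoxycarbonyl)benzyl

The source may report more compounds than this note shows. Statements on the series, on what has been measured and on what is new or still open speak of the compounds shown alone.

Compound 1 `Cc1cc(/C=C2\SC(=S)N(c3ccccc3)C2=O)c(C)n1-c1ccc(O)c(C(=O)O)c1` is the parent of this small set. In an ADME assay on MT2 cells (Homo sapiens) for cytotoxicity, read by XTT assay, with a stated time of 4 days (a lower number here means that less compound is tolerated, a higher number that more compound is tolerated), compound 1 gives > 100000 nM, which is a limit of the assay rather than a measured number, and this is the limit of > 100000 nM in this assay, at which 1 of the 3 values shown sits. Compound 2 `COC(=O)c1ccc(CN2C(=O)/C(=C/c3cc(C)n(-c4ccc(O)c(C(=O)O)c4)c3C)SC2=S)cc1` gives 36900 nM in this assay. Compound 3 `COc1cccc(CN2C(=O)/C(=C/c3cc(C)n(-c4ccc(O)c(C(=O)O)c4)c3C)SC2=S)c1` gives 102000 nM in this assay.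

The measured steps frame the question. There is an at least 2.7-fold lower number from compound 1 to compound 2 (0.43 log units; beyond the scatter), and there is a step that the limit leaves unreadable from compound 1 to compound 3. Between the two benzyl compounds there is a 2.8-fold higher number from compound 2 to compound 3 (0.44 log units; beyond the scatter), so the substituent on the benzyl ring does shift the read-out by a modest amount.

Compound 4 `COC(=O)c1cccc(CN2C(=O)/C(=C/c3cc(C)n(-c4ccc(O)c(C(=O)O)c4)c3C)SC2=S)c1` is the next member. Relative to compound 1 the change is 3-(methoxycarbonyl)benzyl in place of phenyl on an amide-type nitrogen in a ring. The closest measured comparisons are compound 2, which carries the same methoxycarbonyl group on the benzyl ring, and compound 3, which carries a benzyl with a different group.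

Because compound 1 sits at a limit, only a downward step can be read, and a step of the size seen in an at least 2.7-fold lower number from compound 1 to compound 2 (0.43 log units; beyond the scatter) seems the likeliest outcome; the expected step is an at least 2.0-fold lower number from compound 1 to compound 4 (0.30 log units; that floor lies within the scatter). Compound 4 is therefore estimated at 50000 nM, with a range from 20000 nM to 150000 nM.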

Compound 4, half-maximal cytotoxic concentration: 38500 nM
Compound 4: the middle estimate sits 1.3-fold (0.11 log units) above what was measured, and the stated range covers the measured number.
By their numbers in this assay, from the lowest: compounds 2 and 4 (each within the scatter of the next); then compound 3.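

In this assay, the place of the methoxycarbonyl group on the benzyl ring makes no readable difference: there is a 1.0-fold higher number from compound 2 to compound 4 (0.02 log units; within the scatter), so 3-(methoxycarbonyl)benzyl and 4-(methoxycarbonyl)benzyl cannot be told apart here. The group itself does count, since with methoxycarbonyl in place of methoxy on an aromatic carbon there is a 2.6-fold lower number from compound 3 to compound 4 (0.42 log units; beyond the scatter), which leaves the two methoxycarbonyl compounds together and compound 3 apart from them. The step from the parent reads as an at least 2.5-fold lower number from compound 1 to compound 4 (0.41 log units; beyond the scatter), and its true size stays unknown because compound 1 gives a limit of the assay and not a number: the limit of > 100000 nM in this assay, at which 1 of the 4 values shown sits.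

The compounds shown leave open what a plain benzyl with no group on its ring would give, so the part of the benzyl link and the part of the methoxycarbonyl group in the step away from compound 1 cannot be separated. Also open, going by these compounds, is whether a carboxylic acid or an amine in place of the methoxycarbonyl group would read like compound 2 and compound 4 or like compound 3.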